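Flipping a Double Bond: From Compound 2 to Compound 3

The source may report more compounds than this note shows. Statements on the series, on what has been measured and on what is new or still open speak of the compounds shown alone.

Of the compounds shown here, two have so far been tested in a functional assay on K562/Adr cells (Homo sapiens) for cytotoxicity, read by sulforhodamine B assay, with a stated time of 48 h; a lower number here means a stronger inhibitor, a higher number a weaker inhibitor. Compound 1 `CCN(CC)CCCn1c(=O)/c(=C/c2ccc(F)cc2F)s/c1=C1\C(=O)Nc2cc(F)ccc21` gives 4120 nM in this assay. Compound 2 `CCN(CC)CCCn1c(=O)/c(=C/c2cc(OC)c(OC)c(OC)c2)s/c1=C1\C(=O)Nc2ccc(Cl)cc21` gives 1650 nM in this assay, the lower of the two numbers, and the gap to compound 1 lies beyond the usual scatter. Going by the values given here, compound 3 `CCN(CC)CCCn1c(=O)/c(=C/c2cc(OC)c(OC)c(OC)c2)s/c1=C1/C(=O)Nc2ccc(Cl)cc21` is next. the two compounds have the same atoms and bonds and differ only in configuration as drawn: 1 of 2 stereo elements differ; a double bond is drawn Z in compound 2 and E in compound 3 No measured pair shows what such a change does, so a small shift either way, or none beyond the scatter, is possible; the estimate leans toward a slightly higher number, giving an expected step of a 1.5-fold higher number from compound 2 to compound 3 (0.18 log units; within the scatter). Compound 3 is therefore expected to give about 2500 nM, likely between 800 nM and 8000 nM.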

Compound 3, half-maximal inhibitory concentration: 1650 nM
The estimate for compound 3 lay 1.5-fold (0.18 log units) above the measured number, within the range that was stated.
By their numbers in this assay, from the lowest: compounds 2 and 3 (each within the scatter of the next); then compound 1.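

In this assay, going by these compounds alone, this change gives no change at the digits printed from compound 2 to compound 3 (within the scatter) as its result, the first reading of a single change. For this pair, then, drawing this double bond Z or E leaves the number without a shift beyond the scatter. The reading can be tied to this one double bond alone: the fact that compounds 2 and 3 differ only in the configuration as drawn.

On these data alone, whether the same holds when other groups sit on the shared core stays open. So does the effect of replacing the diethylamino end of the side chain with a morpholine or a carboxylic acid.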